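Swapping the Aryl Ring on the Amine Nitrogen

This account rests on a few compounds, and the source may have more. Where it says the series, first, only, none or still open, it means among the compounds named here.

Compound 3, `O=C1C=C(Nc2cccc(Cl)c2)C(=O)c2c1nc1n2[C@H]2OC[C@@H](O)[C@H]2OC1`, was tested in a functional assay on HeLa cells (Homo sapiens) for inhibition, read by sulforhodamine B assay (on this read-out lower numbers stand for stronger inhibition and higher numbers for weaker inhibition), where compound 3 gives 6040 nM. That is the higher of the two numbers in hand, yet the step of a 1.6-fold higher number from compound 1 to compound 3 (0.19 log units; within the scatter) from compound 1, `Cc1ccc(NC2=CC(=O)c3nc4n(c3C2=O)[C@H]2OC[C@@H](O)[C@H]2OC4)cc1`, with a value of 3860 nM, stays within the scatter. Compound 2, `O=C1C=C(Nc2ccc(C(F)(F)F)cc2)C(=O)c2c1nc1n2[C@H]2OC[C@@H](O)[C@H]2OC1`, reaches only the assay limit, > 8000 nM. The steps of an at least 2.0-fold higher number from compound 1 to compound 2 (0.31 log units; beyond the scatter) and an at least 1.3-fold lower number from compound 2 to compound 3 (0.12 log units; that floor lies within the scatter) show that changing the ring on the amine nitrogen moves this read-out at most modestly. Compound 4, `CCOc1ccccc1NC1=CC(=O)c2nc3n(c2C1=O)[C@H]1OC[C@@H](O)[C@H]1OC3`, differs from compound 3 by 2-ethoxyphenyl in place of 3-chlorophenyl on an amine nitrogen. Within the data shown here, no measured step tests an ethoxy group, so the expected step is only a 1.3-fold lower number from compound 3 to compound 4 (0.13 log units; within the scatter). Compound 4 is therefore estimated at 4500 nM, ranging from 1500 nM to 12000 nM.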

Compound 4, half-maximal inhibitory concentration: 6040 nM
For compound 4 the middle estimate is 1.3-fold (0.13 log units) below the measured one; low and high end bracket the measured number.
By their numbers in this assay, from the lowest: compounds 1, 3 and 4 (each within the scatter of the next). At a limit, above all of these: compound 2.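

Among these compounds, the 2-ethoxyphenyl ring brings an oxygen-bearing group to this amine nitrogen for the first time, yet the read-out shows no change at the digits printed from compound 3 to compound 4 (within the scatter). Against the 4-methylphenyl ring the result is a 1.6-fold higher number from compound 1 to compound 4 (0.19 log units; within the scatter), so this ethoxy group, at this ring position, leaves the number within the scatter of both compounds. Compound 2 sits at a limit of the assay, which makes an at least 1.3-fold lower number from compound 2 to compound 4 (0.12 log units; that floor lies within the scatter) only a floor: the limit of > 8000 nM in this assay, at which 1 of the 4 values shown sits.

From the compounds shown here alone, whether a phenyl ring carrying an amine or a carboxylic acid would behave the same remains open. So does the effect of replacing the ring at this nitrogen with a longer alkyl chain.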